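Aryl Swap on the Ring Nitrogen: Expecting No Real Shift

This account rests on a few compounds, and the source may have more. Where it says the series, first, only, none or still open, it means among the compounds named here.

Compound 3 `CCCCN(CC)c1cc(C)nc2c1NC(=O)CN2c1ccc(Br)cc1Cl` gives 2.7 nM in an assay on HEK-293T cells for displacement of a labelled ligand from corticotropin-releasing factor receptor 1 (Homo sapiens), read by scintillation counting, with a stated time of 2 h (on this read-out lower numbers stand for stronger inhibition and higher numbers for weaker inhibition), and among the three numbers recorded this one sits lowest, though the gap to compound 1 is within the usual scatter and allows no order between them. Compound 1 `CCCN(CCC)c1cc(C)nc2c1NC(=O)CN2c1ccc(C(C)C)cc1Br` gives 3.1 nM. Compound 2 `CCN(C)c1cc(C)nc2c1NC(=O)CN2c1ccc(C(C)C)cc1Br` gives 16.4 nM, a number that lies beyond the scatter from that of compound 3. For the measured compounds named here, the only single-point step available, a 5.3-fold higher number from compound 1 to compound 2 (0.72 log units; beyond the scatter), concerns the amino group on the aromatic carbon and not the aryl group on the ring nitrogen. Compound 4 `CCCCN(CC)c1cc(C)nc2c1NC(=O)CN2c1ccc(I)cc1C` differs from compound 3 by 4-iodo-2-methylphenyl in place of 4-bromo-2-chlorophenyl on a nitrogen on an aromatic ring in a ring. Going by the values given here, no measured step touches that aryl group, so nothing recorded here bears directly on this change. Compound 4 is therefore expected to stay close to compound 3, with a step of a 1.3-fold higher number from compound 3 to compound 4 (0.11 log units; within the scatter) that is expected to remain within the scatter. The estimate for compound 4 is 3.5 nM, with a range from 1.2 nM to 10 nM.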

Compound 4, inhibition constant: 3.4 nM
Compound 4: the middle estimate sits 1.0-fold (0.01 log units) above what was measured, within the range that was stated.
By their numbers in this assay, from the lowest: compounds 3, 1 and 4 (each within the scatter of the next); then compound 2.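

In this assay, for the compounds shown here, the step of a 1.3-fold higher number from compound 3 to compound 4 (0.10 log units; within the scatter) is the first measured change to the aryl group on the ring nitrogen, and it stays within the scatter, whereas the earlier single-point step concerned only the amino group on the aromatic carbon. With the amino group held constant, this position therefore accepts 4-iodo-2-methylphenyl in place of 4-bromo-2-chlorophenyl without a readable change, at least for this pair, in which both groups have the same heavy-atom count and neither has a hydrogen-bond donor or acceptor. No measured evidence accompanies this result to explain it.

The compounds shown leave open whether iodine for bromine and methyl for chlorine would each leave the number unchanged alone, or whether they offset one another. They also leave open how the number would respond to an amine or a carboxylic acid on this aryl ring.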